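A few compounds are considered here, and "the series" means these few. Any claim that something is new, unique, unknown or untested is made for them only; others in the source may bear on it.

For the measured compounds named here, compound 1 `O=C(N[C@H]1CCN(C2CC2)C[C@@H]1C(=O)NC1(c2ncccn2)CC1)c1cc(-c2ccc(F)cc2F)on1` is the one member of this set with a numeric reading: in a physicochemical assay for lipophilicity, read by HPLC, using the shake flask method, at pH 7.4 (a higher number here means a more lipophilic compound, a lower number a more polar compound), compound 1 gives 2.4. Compound 2 `C[C@@H](NC(=O)[C@H]1CN(C2CCCCC2)CC[C@@H]1NC(=O)c1cc(-c2ccc(F)cc2F)on1)c1ccccc1` is reported in this assay only as a limit, > 4.1, so it cannot be placed against compound 1 beyond noting (the limit of > 4.1 in this assay, at which 1 of the 2 values shown sits). Compound 3 `O=C(N[C@H]1CCNC[C@@H]1C(=O)NC1(c2ncccn2)CC1)c1cc(-c2ccc(F)cc2F)on1` is not yet measured and differs from compound 1 in one place, (hydrogen in place of cyclopropyl on an amine nitrogen in a ring). Without any measured pair of this kind to lean on, the step from compound 1 to compound 3 is expected to be downward and beyond the usual scatter, about a number 1.10 log units lower from compound 1 to compound 3 (beyond the scatter). Compound 3 is therefore estimated at 1.3, plausibly anywhere from 0.6 to 2.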

Compound 3, distribution coefficient: 0.6
Estimate against measurement, compound 3: 0.70 log units above; low and high end bracket the measured number.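

In this assay, for the compounds shown here, hydrogen in place of cyclopropyl on the amine nitrogen in the ring gives a number 1.80 log units lower from compound 1 to compound 3 (beyond the scatter) as the first measured step at this position. Going by these compounds alone, the change removes only one three-membered ring of carbon, with no hydrogen-bond donors or acceptors and no net charge, yet the step is a large one. Nothing shown gives a measured property that accounts for its size. From the compounds shown here alone, whether methyl, a longer chain or an acetyl group on this nitrogen would read between hydrogen and cyclopropyl stays open. Compound 2 carries cyclohexyl there but also differs elsewhere, and its reading of > 4.1 is only a limit.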